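Ring nitrogen substituent variation in the series

The source may report more compounds than this note shows. Statements on the series, on what has been measured and on what is new or still open speak of the compounds shown alone.

Among the compounds with values here, compound 2 `Nc1scc(CN2CCN(c3ccc(F)cc3Cl)CC2)c1C(=O)c1ccc(Cl)cc1` gives 6.1% in a functional assay on CHO cells with adenosine receptor A1 (Homo sapiens) as the target, read by cAMP accumulation and immunoassay, with a stated time of 6 min, tested at 0.01 uM (on this read-out higher numbers stand for a weaker effect at the one concentration tested and lower numbers for a stronger effect), and stands highest of the three numbers measured so far. Its nearest neighbour is compound 1 `CC(C)N1CCN(Cc2csc(N)c2C(=O)c2ccc(Cl)cc2)CC1` with -1%; the step of a number 7.1 percentage points higher from compound 1 to compound 2 (within the scatter). Furthest is compound 3 `COc1ccc(N2CCN(Cc3csc(N)c3C(=O)c3ccc(Cl)cc3)CC2)cc1` with -1.2%; the step of a number 7.3 percentage points lower from compound 2 to compound 3 (within the scatter). Between compound 1 and compound 3 the step is a number 0.2 percentage points lower from compound 1 to compound 3 (within the scatter).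

The next member is compound 4 `Nc1scc(CN2CCN(c3cccc(C(F)(F)F)c3)CC2)c1C(=O)c1ccc(Cl)cc1`. Against compound 2 the change is 3-(trifluoromethyl)phenyl in place of 2-chloro-4-fluorophenyl on an amine nitrogen in a ring. The same place has been varied twice already: from isopropyl to 2-chloro-4-fluorophenyl, a number 7.1 percentage points higher from compound 1 to compound 2 (within the scatter), and from 2-chloro-4-fluorophenyl to 4-methoxyphenyl, a number 7.3 percentage points lower from compound 2 to compound 3 (within the scatter). Neither left the scatter, so no step beyond the scatter is expected in this assay for a further aryl group on that ring nitrogen; the expected step is a number 4.1 percentage points lower from compound 2 to compound 4 (within the scatter). For compound 4 the estimate in this assay is 2%, with a range from -10% to 14%.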

Compound 4, a percentage reported as activity, at one concentration (the size of the read-out at that concentration, not a potency): -8.2%
Compound 4: the middle estimate sits 10.2 percentage points above what was measured, within the range that was stated.
By their numbers in this assay, from the lowest: compounds 4, 3, 1 and 2 (each within the scatter of the next, the first and the last beyond it).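

In this assay this ring nitrogen gives its first step beyond the scatter (a number 14.3 percentage points lower from compound 2 to compound 4 (beyond the scatter)), a modest one, so a change of aryl group at this position can register on this read-out at the one concentration tested. The separation holds for this pair alone: 3-(trifluoromethyl)phenyl stays within the scatter of 4-methoxyphenyl (a number 7 percentage points lower from compound 3 to compound 4 (within the scatter)) and of isopropyl (a number 7.2 percentage points lower from compound 1 to compound 4 (within the scatter)), so compounds 1 and 3 do not share it. Nothing measured bears on why this one pair separates.

Open, as far as these compounds go, is whether the separation depends on the 2-chloro-4-fluorophenyl group, the 3-(trifluoromethyl)phenyl group or both, which an unsubstituted phenyl group on the same nitrogen could help to settle. Also open, from the compounds shown here alone, is how an acetyl group or a benzyl group at this position would read.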